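Hydrazone arm cut down to a methyl

This account rests on a few compounds, and the source may have more. Where it says the series, first, only, none or still open, it means among the compounds named here.

compound 1 `Nc1c(C(=O)N/N=C/c2ccc(Br)cc2)oc2nc(-c3cccs3)cc(C(F)(F)F)c12`: 6100 nM
compound 2 `Nc1c(C(=O)N/N=C/c2ccc(Cl)cc2)oc2nc(-c3cccs3)cc(C(F)(F)F)c12`: 8100 nM

In a functional assay on HepG2 cells (Homo sapiens) for antiproliferative activity, read by MTT assay (a lower number here means a stronger inhibitor, a higher number a weaker inhibitor), compound 2 gives 8100 nM, within the scatter of compound 1. Compound 3 `CNC(=O)c1oc2nc(-c3cccs3)cc(C(F)(F)F)c2c1N` differs from compound 2 as follows: one carbon atom in place of a group of 9 heavy atoms (7 carbon, 1 nitrogen, 1 chlorine; one six-membered aromatic ring of carbon only), on an amide-type nitrogen. Among the measured compounds shown here, the one measured step, a 1.3-fold higher number from compound 1 to compound 2 (0.12 log units; within the scatter), is only chloro in place of bromo on an aromatic carbon. It leaves the group that departs here in place, so it gives no measure of this far larger change. A modest move to a higher number is expected, estimated as a 2.5-fold higher number from compound 2 to compound 3 (0.39 log units; beyond the scatter). For compound 3 the estimated value is 20000 nM, with an expected range of 6000 nM to 70000 nM.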

Compound 3, half-maximal inhibitory concentration: 12300 nM
Estimate against measurement, compound 3: 1.6-fold (0.21 log units) above; the measured number falls inside the stated range.
By their numbers in this assay, from the lowest: compounds 1, 2 and 3 (each within the scatter of the next).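

The step of a 1.5-fold higher number from compound 2 to compound 3 (0.18 log units; within the scatter) and the step of a 2.0-fold higher number from compound 1 to compound 3 (0.30 log units; within the scatter) in this assay come with the whole hydrazone arm replaced by methyl on the amide-type nitrogen. The earlier pair kept that arm, so only here does it appear that these numbers do not separate compounds with and without the arm and its halogen-bearing aromatic ring. Nothing measured here accounts for this result.

Open, as far as these compounds go, is how other groups on this nitrogen would read, such as a longer alkyl chain, a benzyl group or a simple hydrogen. A carboxylic acid in place of the whole amide is also untested among these compounds.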